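Ethyl on the Amino Nitrogen: From Compound 2 to Compound 4

The source may report more compounds than this note shows. Statements on the series, on what has been measured and on what is new or still open speak of the compounds shown alone.

In a functional assay on the whole organism with Canis familiaris (Canis lupus familiaris) as the target, at a dose of 8 mg/kg by the oral route (a higher number here means a stronger effect of the compound at the dose given, a lower number a weaker effect), three compounds give a first picture. Compound 1 `Cc1nc2c(SCc3ccccc3)cccn2c1N` gives 11%. Compound 2 `Cc1nc2c(CCc3ccccc3)cccn2c1N` gives 52%. Compound 3 `Cc1nc2c(OCc3ccccc3)cccn2c1CN` gives 9%. Compound 2 thus stands highest of the three numbers: the nearest of the others, compound 1, lies lower by a gap beyond the usual scatter, and compound 3 lies lower still, also beyond the scatter. No two of these three compounds differ in only one place, so none of the gaps between them can be read as the effect of a single change.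

Compound 4 `CCNc1c(C)nc2c(CCc3ccccc3)cccn12` has not yet been measured in this assay. It differs from compound 2 in one place: ethyl in place of hydrogen on a nitrogen on an aromatic ring. Among the compounds with values here, nothing among the measured compounds shows what putting ethyl on that nitrogen does, so the size of the step from compound 2 to compound 4 can only be guessed. With no comparable single change among the measured compounds, the step is expected to be small, within or close to the scatter, with wide uncertainty in either direction, and the expected step is a number 10 percentage points lower from compound 2 to compound 4 (within the scatter). Compound 4 is therefore estimated at 42%, expected to fall between 12% and 68%.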

Compound 4, a percentage reported as inhibition, in the whole organism at one dose (the size of the read-out at that dose, not a potency): 65%
Estimate against measurement, compound 4: 23 percentage points below; the range from low to high includes it.
By their numbers in this assay, from the lowest: compounds 3 and 1 (each within the scatter of the next); then compound 2; then compound 4.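

In this assay, within the data shown here, the comparison of compound 2 with compound 4 is the first in this set that isolates one change, and ethyl in place of hydrogen on a nitrogen on an aromatic ring gives a clear, though modest, result (a number 13 percentage points higher from compound 2 to compound 4 (beyond the scatter)). It shows that the effect at this dose does not depend on keeping both hydrogens of the amino group, since amino to ethylamino retains the effect and raises the number beyond the usual scatter, at least with this side chain on the shared core. The compounds shown contain no measurement that explains this rise, and the read-out, taken at a single dose, gives the size of the effect and not a potency.

Going by these compounds, it remains open how the number would respond to a different group on this nitrogen, such as methyl, a longer chain like propyl or butyl, or a second ethyl group. It is also unknown whether ethyl would bring a similar step on the core of compound 1, where the side chain carries a sulfur atom, so the result cannot yet be extended beyond this one pair.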